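Dimethylamino for methoxy on the anisyl ring of compound 2

A few compounds are considered here, and "the series" means these few. Any claim that something is new, unique, unknown or untested is made for them only; others in the source may bear on it.

Among the measured compounds shown here, compound 2 `COc1ccc(C2CC(c3ccccc3)=NN2C2=NC(=O)/C(=C3\C(=O)Nc4ccc(Br)cc43)S2)cc1` gives 240 nM in a functional assay on cells (Cancer cell lines, Homo sapiens) for cytotoxicity, read by sulforhodamine B assay, with a stated time of 48 h (on this read-out lower numbers stand for stronger inhibition of growth and higher numbers for weaker inhibition of growth), the lowest of the three numbers so far. Compound 3 `COc1ccc(C2=NN(C3=NC(=O)/C(=C4\C(=O)Nc5ccc(Br)cc54)S3)C(c3ccc(OC)cc3)C2)cc1` gives 270 nM in this assay, and a 1.1-fold higher number from compound 2 to compound 3 (0.05 log units; within the scatter), so the two stand within the scatter of each other. Compound 1 `COc1ccc(C2CC(c3ccccc3)=NN2C2=NC(=O)/C(=C3\C(=O)Nc4ccccc43)S2)cc1` gives 1520 nM in this assay, and a 6.3-fold lower number from compound 1 to compound 2 (0.80 log units; beyond the scatter).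

Compound 4 `CN(C)c1ccc(C2CC(c3ccccc3)=NN2C2=NC(=O)/C(=C3\C(=O)Nc4ccc(Br)cc43)S2)cc1` differs from compound 2 by dimethylamino in place of methoxy on an aromatic carbon. For the measured compounds named here, no measured step replaces methoxy by dimethylamino, so the expectation rests on indirect evidence. The step from compound 1 to compound 2 concerns the bromo group elsewhere and does not bear on this change. The step from compound 2 to compound 3, which adds a methoxy group on the other aryl ring, stays within the scatter, suggesting that changes on these aryl rings leave this assay little moved. Compound 4 is therefore expected to show a 1.3-fold higher number from compound 2 to compound 4 (0.10 log units; within the scatter), a change not beyond the scatter. The estimate for compound 4 in this assay is 300 nM, with a range from 120 nM to 800 nM.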

Compound 4, concentration for 50% growth inhibition: 270 nM
For compound 4 the middle estimate is 1.1-fold (0.05 log units) above the measured one, and the stated range covers the measured number.
By their numbers in this assay, from the lowest: compounds 2, 3 and 4 (each within the scatter of the next); then compound 1.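

In this assay, dimethylamino in place of methoxy gives a 1.1-fold higher number from compound 2 to compound 4 (0.05 log units; within the scatter), so on this read-out the two groups cannot be told apart at this place, para to a large group. Among the compounds shown here, compounds 1, 2 and 3 all carry the 4-methoxyphenyl group, so they said nothing about a replacement there, and compound 4 gives the only reading of one: 4-(dimethylamino)phenyl is accepted as well as 4-methoxyphenyl in the setting of compound 2. Nothing given here explains this outcome.

The compounds shown leave open whether a primary amine, a carboxylic acid or a longer alkoxy chain at this place would also stay within the scatter of compound 2. They also leave open whether dimethylamino would read the same with hydrogen in place of bromo, as in compound 1.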